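Stereoisomer of compound 1 with three centres inverted

The source may hold more compounds than are shown below. What is called first, only, known or untested is meant among the compounds shown, and "the series" means these compounds.

Compound 1 `COC(=O)[C@@H]1C[C@@]2(CC=C(C)C)c3ccccc3N3C(=N)[C@H](Cc4ccccc4)N1[C@H]32`: in a functional assay on MDA-MB-231 cells (Homo sapiens) for cytotoxicity, read by sulforhodamine B assay, with a stated time of 48 h (a lower number here means that less compound is tolerated, a higher number that more compound is tolerated), compound 1 gives > 100000 nM, which is a limit of the assay.
Compound 2 `COC(=O)[C@@H]1C[C@@]2(CC=C(C)C)c3ccccc3N3C(=N)[C@H](c4ccccc4)N1[C@H]32`: in this assay compound 2 gives > 100000 nM, which is also a limit.

Compound 1 stands at a limit only; (the limit of > 100000 nM in this assay, at which 2 of the 2 values shown sit). Among the measured compounds shown here, the one measured step, a step that the two limits leave unreadable from compound 1 to compound 2, cannot be read. Compound 3 `COC(=O)[C@@H]1C[C@]2(CC=C(C)C)c3ccccc3N3C(=N)[C@@H](Cc4ccccc4)N1[C@@H]32` differs from compound 1 as follows: the two compounds have the same atoms and bonds; at least one stereo element is drawn with a configuration in one of them and without one in the other: 3 of 5 stereo elements differ; a stereocentre at a saturated ring carbon is drawn S in compound 1 and R in compound 3; a stereocentre at a saturated ring carbon is drawn S in compound 1 and R in compound 3; a stereocentre at a saturated ring carbon is drawn R in compound 1 and S in compound 3. For the measured compounds named here, no measured step concerns a change of configuration, so no size or direction of step can be expected in this assay; a limit is expected again. Compound 3 is estimated at 100000 nM, between 30000 nM and 300000 nM. The step this estimate means is expected to be a number no higher from compound 1 to compound 3 (the limit leaves the size open).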

Compound 3, concentration lethal to 50% of the cells: 24100 nM
Compound 3: the middle estimate sits 4.1-fold (0.62 log units) above what was measured, and the stated range ends above it.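

In this assay, configuration alone moves the series off the limit: with no atom or bond changed, the result is an at least 4.1-fold lower number from compound 1 to compound 3 (0.61 log units; beyond the scatter) and lies beyond the scatter. Compound 3 is the only compound shown with a number rather than a limit, so the configuration of the shared core matters in this read-out. Three stereocentres change together, and the step cannot be assigned to any one of them.

Still open, from the compounds shown here alone, is which of the three centres carries the step. Also open, going by these compounds, is how a carboxylic acid in place of the methyl ester would read in the configuration of compound 3.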